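The compounds below may be only part of what the source reports. "The series", "measured", "known", "first", "only" and "open" are said of these compounds alone.

Measured in an ADME assay on cells (Hepatocyte, Homo sapiens) for metabolic stability; a lower number here means that the compound disappears faster, a higher number that the compound lasts longer:

Compound 1 `O=C(Nc1ccc(F)c(Cl)c1)c1ccc(F)c(S(=O)(=O)N2CCCCCC(O)C2)c1`: 0.267 h
Compound 2 `O=C(Nc1ccc(F)c(Cl)c1)c1ccc(F)c(S(=O)(=O)N2CCCCC(O)CC2)c1`: 0.0833 h

Of these two compounds, compound 2 stands lowest, at 0.0833 h, while compound 1 reaches 0.267 h. The next structure is compound 3 `O=C(Nc1ccc(F)c(Cl)c1)c1ccc(F)c(S(=O)(=O)N2CCCCC(O)C2)c1`, which keeps the shared core but alters the group on the sulfonyl sulfur: a group of 8 heavy atoms (6 carbon, 1 nitrogen, 1 oxygen; one seven-membered non-aromatic ring with 1 hetero atom) in place of a group of 9 heavy atoms (7 carbon, 1 nitrogen, 1 oxygen; one eight-membered non-aromatic ring with 1 hetero atom), on a sulfonyl sulfur. It therefore carries 3-hydroxyazepan-1-yl, with a seven-membered ring in place of the eight-membered one.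

Among the compounds with values here, only one measured step bears on this change, and only indirectly: a 3.2-fold lower number from compound 1 to compound 2 (0.51 log units; beyond the scatter). Within the data shown here, that step swaps one eight-membered ring group for another, so no measured pair shows what a change of ring size does. It does show that altering this group alone can move the half-life beyond the usual scatter. With compound 2 at the low end at 0.0833 h, a rise of similar or smaller size seems the likelier outcome, though with little confidence. The expected change is a 2.4-fold higher number from compound 2 to compound 3 (0.38 log units; beyond the scatter). The half-life of compound 3 is estimated at 0.2 h, with an expected range of 0.08 h to 0.5 h.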

Compound 3, half-life: 0.817 h
The estimate for compound 3 lay 4.1-fold (0.61 log units) below the measured number; the whole stated range lies below it.
By their numbers in this assay, from the lowest: compound 2; then compound 1; then compound 3.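

In this assay, the earlier pair had only exchanged one eight-membered ring group for another, whereas 3-hydroxyazepan-1-yl on the sulfonyl sulfur introduces a change of ring size, and the result is a 9.8-fold higher number from compound 2 to compound 3 (0.99 log units; beyond the scatter) and a 3.1-fold higher number from compound 1 to compound 3 (0.49 log units; beyond the scatter). Both steps lie beyond the usual scatter, so compound 3 has the longest half-life of the three, and among these compounds the seven-membered ring gives a higher number than either eight-membered group, with the larger step starting from the group with the lower number. Nothing available explains why the half-life changes with this group.

With a single seven-membered example, the effect of ring size cannot be separated from where the hydroxyl group sits on the ring, a question that 4-hydroxyazepan-1-yl could address. Going by these compounds, it also remains open whether the half-life would keep rising with a smaller ring such as 3-hydroxypiperidin-1-yl or 3-hydroxypyrrolidin-1-yl, and whether azepan-1-yl, which has no hydroxyl group, would keep the number of compound 3.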